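Fluoro in place of acetyl: what compound 3 may show

A few compounds are considered here, and "the series" means these few. Any claim that something is new, unique, unknown or untested is made for them only; others in the source may bear on it.

Compound 1 `CCc1ccc(NC(=O)Nc2cc(C)nc3ccccc23)cc1`: 16000 nM
Compound 2 `CC(=O)c1ccc(NC(=O)Nc2cc(C)nc3ccccc23)cc1`: > 25000 nM (a limit)

In an ADME assay on HEK293 cells (Homo sapiens) for cytotoxicity, with a stated time of 72 h (a higher number here means that more compound is needed for the effect, a lower number that less compound is needed), compound 2 gives > 25000 nM, which is a limit and not a number. That puts it at the limit of > 25000 nM in this assay, at which 1 of the 2 values shown sits. Compound 3 `Cc1cc(NC(=O)Nc2ccc(F)cc2)c2ccccc2n1` carries fluoro in place of acetyl on an aromatic carbon, fluoro in place of acetyl on an aromatic carbon. Among the measured compounds shown here, the only measured step bearing on this is an at least 1.5-fold higher number from compound 1 to compound 2 (0.19 log units; that floor lies within the scatter), which also turns on the acetyl group. For the measured compounds named here, with compound 1 at 16000 nM as the sole number, no step beyond the scatter is expected in this assay. The expected size is an at least 1.2-fold lower number from compound 2 to compound 3 (0.09 log units; that floor lies within the scatter). For compound 3 the estimate is 20000 nM, with an expected range of 9000 nM to 40000 nM.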

Compound 3, half-maximal effective concentration: > 25000 nM
Compound 3: a limit, no number; the forecaster's own chance of this, stated with the estimate: 35%; middle value at least 1.2-fold (0.09 log units) away from the limit.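

Compound 3, with fluoro on the aromatic carbon para to a large group, joins compound 2 at a limit rather than a number in this assay: the limit of > 25000 nM in this assay, at which 2 of the 3 values shown sit.

Ethyl is the only group at this position with a number so far, and fluoro in its place gives an at least 1.5-fold higher number from compound 1 to compound 3 (0.19 log units; that floor lies within the scatter). The step between fluoro and acetyl cannot be read, so the two groups cannot be ordered here.

On these data alone, whether an amine or a longer chain at this position would give a number rather than a limit stays open. As far as these compounds go, the actual values of compound 2 and compound 3 stay open too.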